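This account rests on a few compounds, and the source may have more. Where it says the series, first, only, none or still open, it means among the compounds named here.

Measured so far:
Compound 1, `Cc1cc(O)cc(-c2nn(CC#N)cc2-c2ccnc(-c3ccc(Oc4ccccc4)cc3)c2)c1`: in a functional assay on HCT-116 cells (Homo sapiens) for inhibition, read by sulforhodamine B assay, with a stated time of 48 h (a lower number here means that less compound is tolerated, a higher number that more compound is tolerated), compound 1 gives 5380 nM.
Compound 2, `COc1cc(C)cc(-c2nn(CC#N)cc2-c2ccnc(-c3ccc(N(C)C)cc3)c2)c1`: in this assay compound 2 reaches only the limit > 100000 nM, a bound of the assay rather than a number.

Among the compounds with values here, compound 2 therefore stands at the limit of > 100000 nM in this assay, at which 1 of the 2 values shown sits; of the two compounds measured, it is the one for which no number was obtained, whereas compound 1 gives a number. The compound not yet measured, compound 3, is `Cc1cc(O)cc(-c2nn(CC#N)cc2-c2ccnc(-c3ccc(N(C)C)cc3)c2)c1`. It differs from compound 2 in one place: hydrogen in place of methyl on an oxygen on an aromatic ring. Within the data shown here, compound 1 also carries the hydroxy group, but with a different group at the far end of the molecule, so no single measured pair shows what this one exchange does on its own. The expectation for this assay is that compound 3 is tolerated somewhat less than compound 2, that is a lower number, with the estimated step of an at least 3.3-fold lower number from compound 2 to compound 3 (0.52 log units; beyond the scatter) of uncertain size. Compound 3 is expected to give 30000 nM, with a range from 5000 nM to 100000 nM.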

Compound 3, concentration lethal to 50% of the cells: 41900 nM
For compound 3 the middle estimate is 1.4-fold (0.15 log units) below the measured one, within the range that was stated.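

In this assay, the change from methoxy to hydroxy on the 3-methoxy-5-methylphenyl group gives an at least 2.3-fold lower number from compound 2 to compound 3 (0.37 log units; beyond the scatter), so the exchange on this oxygen can now be read on its own, and the compound with the hydroxy group is tolerated less. The true size of this step stays unknown, because compound 2 gives a limit of the assay and not a number: the limit of > 100000 nM in this assay, at which 1 of the 3 values shown sits.

Within the data shown here, compound 3 also forms a second pair that the earlier compounds could not provide: with the hydroxy group held fixed, dimethylamino in place of phenoxy on an aromatic carbon gives a 7.8-fold higher number from compound 1 to compound 3 (0.89 log units; beyond the scatter), so this other place also matters in this assay.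

On these data alone, the exchange from methoxy to hydroxy is seen here only alongside dimethylamino, so whether it has a similar size alongside phenoxy remains open. Also open, as far as these compounds go, is how this assay would respond to an ethyl group or a longer chain on this oxygen, or to an amine in its place.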